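A few compounds are considered here, and "the series" means these few. Any claim that something is new, unique, unknown or untested is made for them only; others in the source may bear on it.

Compound 1 `CC1=NN(C(=O)CSc2ccccn2)[C@@H](c2cc(Br)cc(Br)c2O)C1`: 12300 nM
Compound 2 `CC1=NN(C(=O)CSc2ccccc2)[C@@H](c2cc(Br)cc(Br)c2O)C1`: 12700 nM
Compound 3 `O=C(CSc1ccc([N+](=O)[O-])cc1)N1N=C(c2cc3ccccc3oc2=O)C[C@@H]1c1ccccc1C(F)(F)F`: 7580 nM

In a functional assay on MGC-803 cells (Homo sapiens) for cytotoxicity, read by MTT assay, with a stated time of 48 h (on this read-out higher numbers stand for weaker inhibition and lower numbers for stronger inhibition), compound 3 gives 7580 nM. That number lies within the usual scatter of the numbers for compound 1 and compound 2, so these three compounds cannot be ranked.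

Compound 4 `O=C(CSc1ccc(Br)cc1)N1N=C(c2cc3ccccc3oc2=O)C[C@@H]1c1ccccc1C(F)(F)F` is compound 3 with one change: bromo in place of nitro on an aromatic carbon. In words, bromo takes the place of nitro on an aromatic carbon, para to a large group. Going by the values given here, no measured pair makes this exchange. Among the compounds with values here, the only measured step, a 1.0-fold higher number from compound 1 to compound 2 (0.01 log units; within the scatter), concerns phenyl in place of pyridin-2-yl on a sulfur, so it offers only indirect guidance. It does show one swap of a terminal ring that left the number unchanged within the scatter. On that thin evidence, no shift beyond the scatter is expected in this assay, and no direction can be favoured. The expected change is a 1.1-fold higher number from compound 3 to compound 4 (0.02 log units; within the scatter). For compound 4 the estimated value is 8000 nM, with an expected range from 3000 nM to 20000 nM.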

Compound 4, half-maximal inhibitory concentration: 21300 nM
Beside the measured number, compound 4's estimate is 2.7-fold (0.43 log units) below it; measured number outside the range, above it.
By their numbers in this assay, from the lowest: compounds 3, 1, 2 and 4 (each within the scatter of the next, the first and the last beyond it).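

Swapping nitro for bromo, in this assay, gives a 2.8-fold higher number from compound 3 to compound 4 (0.45 log units; beyond the scatter), a modest but readable shift toward weaker inhibition. Going by these compounds alone, the earlier step, a 1.0-fold higher number from compound 1 to compound 2 (0.01 log units; within the scatter), changed a terminal ring on a different core and left no readable difference, so this pair is the first to show that a single group on a terminal ring can move the number, here on an aromatic carbon para to a large group. Nothing measured here accounts for the shift.

With only nitro and bromo at this place, the compounds shown leave open where an amine, a methoxy group or a plain hydrogen would fall. They also leave open whether the same exchange would move the number in the same direction on the core of compound 2.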